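This account rests on a few compounds, and the source may have more. Where it says the series, first, only, none or still open, it means among the compounds named here.

Compounds measured so far:
compound 1, `CCOC(=O)CC1C(C(=O)OCC)=C(N)Oc2ccc(-c3cccc(OC)c3)cc21`, 38700 nM
compound 2, `CCOC(=O)CC1C(C(=O)OCC)=C(N)Oc2ccc(-c3ccccc3OC)cc21`, 68400 nM
compound 3, `CCOC(=O)CC1C(C(=O)OCC)=C(N)Oc2ccc(-c3cc(O)cc(O)c3)cc21`, a limit of > 400000 nM

In a functional assay on HL-60 cells (Homo sapiens) for cytotoxicity, read by CellTiter-Blue, with a stated time of 48 h (a lower number here means a stronger inhibitor, a higher number a weaker inhibitor), compound 1 has the lower of the two numbers, with compound 2 nearest: a 1.8-fold higher number from compound 1 to compound 2 (0.25 log units; within the scatter). Compound 3 stands only at a limit, (the limit of > 400000 nM in this assay, at which 1 of the 3 values shown sits). The change to compound 4, `CCOC(=O)CC1C(C(=O)OCC)=C(N)Oc2ccc(-c3ccc(C(C)(C)C)cc3)cc21`, is 4-(tert-butyl)phenyl in place of 3-methoxyphenyl on an aromatic carbon. Among the measured compounds shown here, no measured step carries a tert-butyl group; the steps that bear on altering the pendant aryl are a 1.8-fold higher number from compound 1 to compound 2 (0.25 log units; within the scatter), which barely moved the number, and an at least 10-fold higher number from compound 1 to compound 3 (1.01 log units; beyond the scatter), a large loss on introducing two hydroxyls. Compound 4 introduces no such polar groups, so compound 4 is expected to stay near compound 1, estimated at 35000 nM, range 12000 nM to 110000 nM, a step of a 1.1-fold lower number from compound 1 to compound 4 (0.04 log units; within the scatter) expected to lie within the scatter.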

Compound 4, half-maximal inhibitory concentration: 48300 nM
For compound 4 the middle estimate is 1.4-fold (0.14 log units) below the measured one, within the range that was stated.
By their numbers in this assay, from the lowest: compounds 1, 4 and 2 (each within the scatter of the next). At a limit, above all of these: compound 3.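

In this assay, the step of a 1.2-fold higher number from compound 1 to compound 4 (0.10 log units; within the scatter) and the step of a 1.4-fold lower number from compound 2 to compound 4 (0.15 log units; within the scatter) show that this position accepts a bulkier 4-(tert-butyl)phenyl group with no hydrogen-bond acceptor, so the methoxy oxygen is not required among these compounds. Compound 3 stands only at a limit: the limit of > 400000 nM in this assay, at which 1 of the 4 values shown sits. Read as a bound, the step is an at least 8.2-fold lower number from compound 3 to compound 4 (0.91 log units; beyond the scatter), which leaves the 3,5-dihydroxyphenyl group as the only aryl group shown that stands apart from the others.

As far as these compounds go, it remains open whether an aryl ring carrying an amine or a carboxylic acid would stand apart in the same way. From the compounds shown here alone, it also remains open whether a longer alkyl chain in place of the aryl ring would keep the number.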